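A few compounds are considered here, and "the series" means these few. Any claim that something is new, unique, unknown or untested is made for them only; others in the source may bear on it.

Compound 3 `CN1CCN(c2ccc(Nc3nc(-c4cccc(NC(=O)c5ccc(Cl)cc5)c4)sc3C(=O)O)cc2)CC1` gives 71.6% in a functional assay on Ramos cells (Homo sapiens) for antiproliferative activity, read by CCK-8 assay, with a stated time of 72 h, tested at 40 uM (a lower number here means less inhibition, a higher number more inhibition at the concentration tested (going by the name of the read-out)), the lowest of the three measured numbers; compound 1 `CCOC(=O)c1sc(-c2cccc(NC(=O)c3ccc(F)c(Cl)c3)c2)nc1Nc1ccc(N2CCN(C)CC2)cc1` at 72.5% lies within the scatter of it, while compound 2 `CN1CCN(c2ccc(Nc3nc(-c4cccc(NC(=O)c5cccc(F)c5)c4)sc3C(=O)O)cc2)CC1` at 82.7% lies beyond it. Compound 4 `CN1CCN(c2ccc(Nc3nc(-c4cccc(NC(=O)c5ccc(F)c(Cl)c5)c4)sc3C(=O)O)cc2)CC1` differs from compound 3 by 3-chloro-4-fluorophenyl in place of 4-chlorophenyl on a carbonyl carbon. Within the data shown here, the one measured step at that carbonyl carbon, a number 11.1 percentage points lower from compound 2 to compound 3 (beyond the scatter), swapped a different pair of phenyl groups, so it bears only loosely on this change. Compound 1 already carries the 3-chloro-4-fluorophenyl group and sits within the scatter of compound 3. The expected step in this assay is therefore a number 1.4 percentage points higher from compound 3 to compound 4 (within the scatter), which stays within the scatter. The estimate for compound 4 is 73%, with a range from 62% to 84%.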

Compound 4, a percentage reported as inhibition, at one concentration (the size of the read-out at that concentration, not a potency): 98.6%
Compound 4: the middle estimate sits 25.6 percentage points below what was measured; the measured number lies above the stated range.
By their numbers in this assay, from the lowest: compounds 3 and 1 (each within the scatter of the next); then compound 2; then compound 4.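

At the carbonyl carbon, 3-chloro-4-fluorophenyl gives more inhibition than either other phenyl group in this assay, with a number 27 percentage points higher from compound 3 to compound 4 (beyond the scatter) and a number 15.9 percentage points higher from compound 2 to compound 4 (beyond the scatter) as the two steps beyond the scatter. The group alone does not set the number, since hydrogen in place of ethyl on the oxygen gives a number 26.1 percentage points higher from compound 1 to compound 4 (beyond the scatter) with the phenyl group unchanged. No measurement at hand accounts for these steps. The compounds shown leave open how 3,4-dichlorophenyl would read at that carbonyl carbon, and whether a primary amide could stand in for the carboxylic acid.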